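This account rests on a few compounds, and the source may have more. Where it says the series, first, only, none or still open, it means among the compounds named here.

Of the compounds shown here, three built on one shared core have been tested in a functional assay on CCRF-CEM cells (Homo sapiens) for antiproliferative activity, read by MTT assay, with a stated time of 96 h; on this read-out higher numbers stand for weaker inhibition and lower numbers for stronger inhibition. Compound 1 `CCN(CC)c1ccc(N2C(=O)NC3(CSC4=C3C(=O)c3ncccc3C4=O)C2=O)cc1` gives 20 nM, the lowest number of the three. Compound 2 `COc1ccc(N2C(=O)NC3(CSC4=C3C(=O)c3ncccc3C4=O)C2=O)cc1` gives 50 nM, and compound 3 `CCCCc1ccc(N2C(=O)NC3(CSC4=C3C(=O)c3ncccc3C4=O)C2=O)cc1` gives 150 nM. The two measured steps away from compound 1 are a 2.5-fold higher number from compound 1 to compound 2 (0.40 log units; beyond the scatter) and a 7.5-fold higher number from compound 1 to compound 3 (0.88 log units; beyond the scatter), both modest rises. Compound 4 `O=C1C2=C(C(=O)c3ncccc31)C1(CS2)NC(=O)N(c2ccc([N+](=O)[O-])cc2)C1=O` carries a change of the same kind: nitro in place of diethylamino on an aromatic carbon. The nitro group is not among the groups already measured, so only those two steps guide the expectation, and each swap away from diethylamino so far has weakened inhibition. A modest rise, a 4.0-fold higher number from compound 1 to compound 4 (0.60 log units; beyond the scatter), is therefore expected. Compound 4 is estimated to give 80 nM, within a range from 25 nM to 300 nM.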

Compound 4, half-maximal inhibitory concentration: 1 nM
For compound 4 the middle estimate is 80-fold (1.90 log units) above the measured one, outside the stated range (below it).
By their numbers in this assay, from the lowest: compound 4; then compound 1; then compound 2; then compound 3.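

Within the data shown here, this position on the aromatic ring, para to a large group, allows far stronger inhibition than the earlier compounds revealed, since nitro in place of diethylamino gives a 20-fold lower number from compound 1 to compound 4 (1.30 log units; beyond the scatter). Nitro also gives a 50-fold lower number from compound 2 to compound 4 (1.70 log units; beyond the scatter) and a 150-fold lower number from compound 3 to compound 4 (2.18 log units; beyond the scatter), so these steps dwarf the differences among the three earlier groups. No available measurement explains why nitro stands apart. On these data alone, whether a nitrile or a carboxylic acid at this position would match nitro remains open. So does whether nitro would bring such a gain on a different core.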